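Acetylpiperidinyl replaces the pyridinyl amide on the shared core

This account rests on a few compounds, and the source may have more. Where it says the series, first, only, none or still open, it means among the compounds named here.

Within the data shown here, compound 1 `CNC(=O)c1ccc(-c2cnc(NCc3c(F)ccc4c3CCO4)c3cn[nH]c(=O)c23)c(C)n1` gives 23 mL.min-1.g-1 in an ADME assay on microsomes from liver (Homo sapiens) for metabolic stability, read by LC-MS, using NADPH, with stated times of 5 min and 30 min, tested at 1 uM (a higher number here means faster removal of the compound, a lower number slower removal), the lowest of the two numbers known there. Compound 3 `CN(c1cccnc1)c1cnc(NCc2c(F)ccc3c2CCO3)n2cnnc12` gives 80 mL.min-1.g-1 in this assay. For compound 2 `O=C1CC2(CC2)CN1c1cnc(NCc2c(F)ccc3c2CCO3)n2cnnc12` the measurement in this assay is only a limit, < 3 mL.min-1.g-1. Among the measured compounds shown here, the single measured step, an at least 26-fold higher number from compound 2 to compound 3 (1.42 log units; beyond the scatter), involves a different core and a different pair of groups, so it does not bear directly on the change from compound 1 to compound 4 `CC(=O)N1CCC(c2cnc(NCc3c(F)ccc4c3CCO4)c3cn[nH]c(=O)c23)CC1`, (1-acetylpiperidin-4-yl in place of 2-methyl-6-(methylcarbamoyl)pyridin-3-yl on an aromatic carbon). For the measured compounds named here, no measured step speaks to this particular swap. Compound 4 is therefore expected to remain close to compound 1, with a step of a 1.0-fold lower number from compound 1 to compound 4 (0.02 log units; within the scatter). The estimate for compound 4 in this assay is 22 mL.min-1.g-1, expected to fall between 8 mL.min-1.g-1 and 55 mL.min-1.g-1.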

Compound 4, intrinsic clearance in microsomes: 207 mL.min-1.g-1
For compound 4 the middle estimate is 9.4-fold (0.97 log units) below the measured one, outside the stated range (above it).
By their numbers in this assay, from the lowest: compound 1; then compound 3; then compound 4. At a limit, below all of these: compound 2.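

In this assay, among these compounds, the swap of 2-methyl-6-(methylcarbamoyl)pyridin-3-yl for 1-acetylpiperidin-4-yl gives a 9.0-fold higher number from compound 1 to compound 4 (0.95 log units; beyond the scatter) and shows that the number responds clearly to the group on this aromatic carbon of the shared core, which no earlier pair showed. The change replaces an aromatic ring with a non-aromatic one and also removes the amide hydrogen donor, so this single step cannot separate the two. Nothing shown gives a measured reason for the rise. On these data alone, whether a plain pyridine ring or a piperidine bearing a methylcarbamoyl group would stand nearer compound 1 remains open.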